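A halogen exchange on the amide-type nitrogen

A few compounds are considered here, and "the series" means these few. Any claim that something is new, unique, unknown or untested is made for them only; others in the source may bear on it.

Measured so far in an in vitro ADME assay on microsomes from liver (Homo sapiens) for pharmacokinetics, read by LC-MS, with a stated time of 10 min, tested at 1 uM (a lower number here means slower removal, a higher number faster removal of the compound), are three compounds:
Compound 1 `CC(C)c1ccc(NC(=O)[C@H]2CN(C)C[C@@H]2c2ccc(/C=C/C(=O)Nc3ccccc3N)cc2)cc1` gives 10 mL/min/kg as its clearance
Compound 2 `COc1cccc(NC(=O)[C@H]2CN(C)C[C@@H]2c2ccc(/C=C/C(=O)Nc3ccccc3N)cc2)c1` gives 14 mL/min/kg as its clearance
Compound 3 `CN1C[C@H](C(=O)Nc2ccc(F)c(Br)c2)[C@@H](c2ccc(/C=C/C(=O)Nc3ccccc3N)cc2)C1` gives 15 mL/min/kg as its clearance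

The steps that reach compound 3 are a 1.1-fold higher number from compound 2 to compound 3 (0.03 log units; within the scatter) and a 1.5-fold higher number from compound 1 to compound 3 (0.18 log units; within the scatter) and neither of them leaves the scatter, so compound 3 cannot be separated from the other two compounds. The next structure is compound 4 `CN1C[C@H](C(=O)Nc2ccc(Cl)c(Cl)c2)[C@@H](c2ccc(/C=C/C(=O)Nc3ccccc3N)cc2)C1` and it differs from compound 3 by a single exchange 3,4-dichlorophenyl in place of 3-bromo-4-fluorophenyl on an amide-type nitrogen in which 3,4-dichlorophenyl stands in place of 3-bromo-4-fluorophenyl on an amide-type nitrogen.

All three measured steps bear on this change, since each of them exchanges the group at this same nitrogen. The third is a 1.4-fold higher number from compound 1 to compound 2 (0.15 log units; within the scatter) and it also stays within the scatter. Within the data shown here, no measured compound carries the 3,4-dichlorophenyl group, so the expectation rests on these steps and on compound 3 at 15 mL/min/kg as the starting point. In this assay no step beyond the scatter is expected, in either direction. The estimated step is a 1.1-fold lower number from compound 3 to compound 4 (0.03 log units; within the scatter) and it would not be distinguishable from repeat measurement. Compound 4 is expected at 14 mL/min/kg with an estimated range from 8 mL/min/kg to 24 mL/min/kg once it is measured.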

Compound 4, clearance: 14 mL/min/kg
Beside the measured number, compound 4's estimate shows no gap at the digits printed; the measured number falls inside the stated range.
By their numbers in this assay, from the lowest: compounds 1, 2, 4 and 3 (each within the scatter of the next).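

In this assay, among these compounds, the exchange of 3-bromo-4-fluorophenyl for 3,4-dichlorophenyl on the amide-type nitrogen gives a 1.1-fold lower number from compound 3 to compound 4 (0.03 log units; within the scatter), so a change confined to the halogens of the ring, at an equal count of heavy atoms, produces no step that can be told from repeat measurement. Among the compounds shown here, the new group also stays within the scatter of the two non-halogen groups, with no change at the digits printed from compound 2 to compound 4 (within the scatter) and a 1.4-fold higher number from compound 1 to compound 4 (0.15 log units; within the scatter), which extends the flat reading at this position to four aryl groups, with no compound among them going against it. Nothing measured here accounts for this insensitivity of the clearance to the group on this nitrogen.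

From the compounds shown here alone, all four compounds carry a substituted phenyl group on this nitrogen, so it remains open whether the clearance would stay within the scatter with a carboxylic acid or an amine on that ring, or with a longer alkyl chain in place of the ring. The shared core is also constant throughout, which leaves open how the clearance would respond to a change anywhere else in the structure, such as on the ring nitrogen's methyl group.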